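The source may hold more compounds than are shown below. What is called first, only, known or untested is meant among the compounds shown, and "the series" means these compounds.

Measured so far:
compound 1 `CCN(CC)S(=O)(=O)c1ccc(S(=O)(=O)N2CCC[C@@H](C(=O)NC3CCOCC3)C2)cc1`: 3770 nM
compound 2 `CN(C)S(=O)(=O)c1ccc(S(=O)(=O)N2CCC[C@@H](C(=O)N3CCC(F)(F)CC3)C2)cc1`: 118 nM

Both numbers come from a functional assay on MIA PaCa-2 cells (Homo sapiens) for inhibition, read by MTT assay, with a stated time of 7 days; on this read-out higher numbers stand for weaker inhibition and lower numbers for stronger inhibition. On them compound 1 stands at the top: its number is the higher of the two, and compound 2 gives a lower one, a gap that lies beyond the scatter. Going by the values given here, compound 2 differs from compound 1 in more than one place, so no single step between the two can be read off.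

Compound 3 `CCN(CC)S(=O)(=O)c1ccc(S(=O)(=O)N2CCC[C@@H](C(=O)N3CCS(=O)(=O)CC3)C2)cc1` has not yet been measured. It keeps the core of compound 1 and makes one change: 1,1-dioxothiomorpholin-4-yl in place of (oxan-4-yl)amino on a carbonyl carbon. A group with an amide hydrogen gives way to one without. Among the compounds with values here, no measured pair shows this change alone. Compound 2 also carries a ring without an amide hydrogen on the carbonyl carbon and gives the lower number, but its other change prevents any firm reading. The expected step of a 3.1-fold lower number from compound 1 to compound 3 (0.50 log units; beyond the scatter) is a modest move toward stronger inhibition. Compound 3 is expected to give 1200 nM in this assay, within a range from 300 nM to 5000 nM.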

Compound 3, half-maximal inhibitory concentration: 900 nM
For compound 3 the middle estimate is 1.3-fold (0.12 log units) above the measured one; the measured number falls inside the stated range.
By their numbers in this assay, from the lowest: compound 2; then compound 3; then compound 1.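

In this assay, placing 1,1-dioxothiomorpholin-4-yl instead of (oxan-4-yl)amino on the carbonyl carbon gives a 4.2-fold lower number from compound 1 to compound 3 (0.62 log units; beyond the scatter), a step beyond the scatter. Going by these compounds alone, this is the first reading of a change at this position alone, with the rest of compound 1 kept, whereas compound 2 differs from compound 1 in more than one place. Nothing measured here explains the step, which removes the amide hydrogen and replaces the ring in a single move.

The compounds shown leave open whether the loss of the amide hydrogen or the change of ring accounts for the step. A morpholin-4-yl group or a methyl(oxan-4-yl)amino group on the same carbonyl carbon would help separate these two parts of the change.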